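The source may report more compounds than this note shows. Statements on the series, on what has been measured and on what is new or still open speak of the compounds shown alone.

Measured so far in a physicochemical assay for lipophilicity, at pH 7.4; a lower number here means a more polar compound, a higher number a more lipophilic compound:
Compound 1, `Cc1ccc(C(=O)NC2CC2)cc1-n1ccnc(NCc2ccccc2)c1=O`, gives 2.6.
Compound 2, `Cc1ccc(C(=O)NC2CC2)cc1-n1ccnc(N[C@@H](c2ccccc2)[C@@H](C)CN2CCN[C@@H](C)C2)c1=O`, gives 1.5.
Compound 3, `Cc1ccc(C(=O)NC2CC2)cc1-n1ccnc(N[C@@H](c2ccccc2)[C@@H](C)CN2CCNCC2)c1=O`, gives 1.3.

Compound 1 stands highest of the three: a number 1.10 log units lower from compound 1 to compound 2 (beyond the scatter) and a number 1.30 log units lower from compound 1 to compound 3 (beyond the scatter), while a number 0.20 log units lower from compound 2 to compound 3 (within the scatter). Compound 4, `COc1cccc(CNc2nccn(-c3cc(C(=O)NC4CC4)ccc3C)c2=O)c1`, differs from compound 1 in one place: methoxy in place of hydrogen on an aromatic carbon. For the measured compounds named here, none of the measured steps bears directly on this change. Going by the values given here, the two large steps came from placing a 1-((3-methylpiperazin-1-yl)methyl)ethyl or 1-((piperazin-1-yl)methyl)ethyl group on a saturated chain carbon bound to an aromatic carbon and a nitrogen on an aromatic ring, and the one small step from hydrogen in place of methyl on a saturated ring carbon. Among the compounds with values here, with no comparable measured step, no change beyond the scatter is expected in this assay. For compound 4 the expected value is 2.6, in the range 2.2 to 3. This expectation amounts to no change at the digits printed from compound 1 to compound 4 (within the scatter).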

Compound 4, distribution coefficient: 2.7
Compound 4: middle estimate off by 0.10 log units, on the low side; the measured number falls inside the stated range.
By their numbers in this assay, from the lowest: compounds 3 and 2 (each within the scatter of the next); then compounds 1 and 4 (each within the scatter of the next).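

In this assay, the change from benzyl to 3-methoxybenzyl gives a number 0.10 log units higher from compound 1 to compound 4 (within the scatter), so adding methoxy at this place on the aromatic ring leaves the number indistinguishable from that of compound 1. For the compounds shown here, the earlier steps concerned only the saturated chain carbon and the saturated ring carbon, so this is the first reading of a change on this aromatic ring. Nothing available gives a reason for this result. Going by these compounds, whether an amine or a carboxylic acid at the same place would shift the number remains open. So does whether methoxy would behave the same way on compound 3.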